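A few compounds are considered here, and "the series" means these few. Any claim that something is new, unique, unknown or untested is made for them only; others in the source may bear on it.

Measured so far in a functional assay on the whole organism (strain Wistar) for inhibition, with Rattus norvegicus as the target, read by paw edema, with stated times of 60 min and 2 h, at a dose of 100 mg/kg by the oral route; a lower number here means less inhibition, a higher number more inhibition at the dose given (going by the name of the read-out):
compound 1 `COc1cc2c(cc1OC)C(CC(=O)NC(C)(C)C)CC2` — 32%
compound 2 `CCCCCCNC(=O)CC1CCc2cc(OC)c(OC)cc21` — 41.5%

Going by the values given here, compound 2 holds the higher of the two numbers in this assay, yet the one step between them, a number 9.5 percentage points higher from compound 1 to compound 2 (within the scatter), is within the scatter, so the two compounds cannot be put in order. That step exchanges one saturated chain on the amide-type nitrogen for another and leaves the shared core untouched.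

Compound 3 `COc1cc2c(cc1OC)C(CC(=O)NCCO)CC2` is not yet measured. It differs from compound 2 by hydroxy in place of butyl on a saturated chain carbon, two bonds along the chain from an amide-type nitrogen. Cut one bond further out, the same change reads hexyl to 2-hydroxyethyl.

Among the compounds with values here, only one measured step exists, and it bears on this change loosely: it swaps tert-butyl for hexyl on the amide-type nitrogen, and a number 9.5 percentage points higher from compound 1 to compound 2 (within the scatter) stays within the scatter. Within the data shown here, no measured pair brings in a hydroxy group; the numbers at hand say nothing about how a hydroxy two bonds along the chain from the amide-type nitrogen would read in this assay. The expectation therefore rests on that single step alone, and the step of a number 5.5 percentage points lower from compound 2 to compound 3 (within the scatter) is expected to stay within the scatter. Compound 3 is estimated at 36%, with a range from 20% to 52%.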

Compound 3, a percentage reported as inhibition, in the whole organism at one dose (the size of the read-out at that dose, not a potency): 0%
The estimate for compound 3 lay 36 percentage points above the measured number; the whole stated range lies above it.
By their numbers in this assay, from the lowest: compound 3; then compounds 1 and 2 (each within the scatter of the next).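

The amide-nitrogen substituent now makes a clear difference in (this assay), which the earlier pair could not show, as tert-butyl and hexyl stayed within the scatter of each other. Hydroxy in place of butyl on a saturated chain carbon, two bonds along the chain from an amide-type nitrogen, gives a large change (a number 41.5 percentage points lower from compound 2 to compound 3 (beyond the scatter)), and 2-hydroxyethyl in place of tert-butyl on the same nitrogen gives another (a number 32 percentage points lower from compound 1 to compound 3 (beyond the scatter)), so compound 3 with its reading of (0%) stands apart from both earlier compounds. Nothing available explains why this change reads as it does.

Compound 3 removes butyl and brings in hydroxy in a single change, so the compounds shown do not separate the effect of the shorter chain from that of the hydroxy group; a plain ethyl, a 2-methoxyethyl or a 6-hydroxyhexyl chain on the same nitrogen would pull these two apart. Also open, as far as these compounds go, is how an amine or a carboxylic acid at the end of the chain, in place of hydroxy, would read at this dose.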